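Aryl swap on the ring nitrogen: compound 3 to compound 4

This account rests on a few compounds, and the source may have more. Where it says the series, first, only, none or still open, it means among the compounds named here.

Three compounds in the series have numbers in a functional assay on PC-3 cells (Homo sapiens) for cytotoxicity, read by MTT assay, with a stated time of 72 h; a lower number here means a stronger inhibitor, a higher number a weaker inhibitor. Compound 1 `Cc1ccc(-n2nc(C(=O)Nc3ccc(Oc4ncnc5[nH]ccc45)cc3)c(C)cc2=O)cc1` gives 9610 nM. Compound 2 `Cc1cc(=O)n(-c2ccc(Br)cc2F)nc1C(=O)Nc1ccc(Oc2ncnc3[nH]ccc23)cc1` gives 2730 nM. Compound 3 `Cc1cc(=O)n(-c2ccc(Br)cc2F)nc1C(=O)Nc1ccc(Oc2ncnc3c2ccn3C)cc1` gives 18800 nM, which is the highest of the three numbers; compound 1 sits nearest to it, within the scatter, while compound 2 sits furthest, beyond it. Among the measured compounds shown here, the step of a 6.9-fold higher number from compound 2 to compound 3 (0.84 log units; beyond the scatter) is the only one that touches the group on the other aromatic nitrogen, and it is the larger of the two known steps.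

Compound 4 `Cc1cc(=O)n(-c2ccccc2C(F)(F)F)nc1C(=O)Nc1ccc(Oc2ncnc3c2ccn3C)cc1` is not yet measured in this assay. It differs from compound 3 by 2-(trifluoromethyl)phenyl in place of 4-bromo-2-fluorophenyl on an aromatic nitrogen. For the measured compounds named here, the single measured step that bears on this position is a 3.5-fold lower number from compound 1 to compound 2 (0.55 log units; beyond the scatter), a modest step that went with a change of aryl on the same nitrogen. Going by the values given here, no measured pair shows a group carrying trifluoromethyl at that position, so the direction for compound 4 is not fixed by the series; the one known aryl change was modest, and the change from compound 3 to compound 4 is expected to be of similar modest size or within the scatter, with the aryl of compound 3 carrying the more favourable record.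

For compound 4 the expected step is a 1.3-fold higher number from compound 3 to compound 4 (0.12 log units; within the scatter). Compound 4 is therefore estimated at 25000 nM, with a range from 9000 nM to 70000 nM.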

Compound 4, half-maximal inhibitory concentration: 19100 nM
Beside the measured number, compound 4's estimate is 1.3-fold (0.12 log units) above it, within the range that was stated.
By their numbers in this assay, from the lowest: compound 2; then compounds 1, 3 and 4 (each within the scatter of the next).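

In this assay the exchange of 4-bromo-2-fluorophenyl for 2-(trifluoromethyl)phenyl on the aromatic nitrogen gives a 1.0-fold higher number from compound 3 to compound 4 (0.01 log units; within the scatter) and so, unlike a 3.5-fold lower number from compound 1 to compound 2 (0.55 log units; beyond the scatter) with hydrogen on the other aromatic nitrogen, shows an aryl change at this position that leaves the number within the scatter. With methyl on that other nitrogen, both the bromine and the fluorine can be lost and a trifluoromethyl group introduced with no readable change, so on this background the two aryl groups cannot be told apart. No measurement on these compounds offers an explanation for this result.

The compounds shown leave open whether the same aryl exchange would also leave the number unchanged with hydrogen on the other aromatic nitrogen, as in compound 2 at 2730 nM in this series. Also open, from the compounds shown here alone, is how this position would respond to a carboxylic acid or an amine on the aryl group, or to a longer chain in place of that group.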